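The source may report more compounds than this note shows. Statements on the series, on what has been measured and on what is new or still open speak of the compounds shown alone.

Measured compounds in a functional assay on U-87MG ATCC cells (Homo sapiens) for cytotoxicity, read by MTT assay, with a stated time of 72 h; a higher number here means a weaker inhibitor, a lower number a stronger inhibitor:
compound 1, `COc1cc2c(Oc3ccc(NC(=O)c4nnn(-c5ccc(F)cc5)c4C(F)(F)F)cc3F)ccnc2cc1OCCCN1CCCC1`, 850 nM
compound 2, `COc1cc2c(Oc3ccc(NC(=O)c4nnn(-c5ccc(F)cc5)c4C(F)(F)F)cc3F)ccnc2cc1OCCCN1CCCCC1`, 1100 nM
compound 3, `COc1cc2c(Oc3ccc(NC(=O)c4nnn(-c5ccc(F)c(F)c5)c4C(F)(F)F)cc3F)ccnc2cc1OCCCN1CCCCC1`, 1210 nM

The three numbers fall close together. Compound 2 sits between the other two: the gap to compound 3 and the gap to compound 1 are both within the scatter, so no ordering among the three can be read from these values.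

Compound 4, `COc1cc2c(Oc3ccc(NC(=O)c4nnn(-c5ccc(F)cc5)c4C(F)(F)F)cc3F)ccnc2cc1OCCCN1CCC(C)CC1`, differs from compound 2 by methyl in place of hydrogen on a saturated ring carbon; the whole of the rest of the molecule, including the shared core and the three-carbon chain from the aromatic oxygen to the ring nitrogen, is kept.

Within the data shown here, two measured steps bear on this. The closer one is a 1.3-fold higher number from compound 1 to compound 2 (0.11 log units; within the scatter), which also altered the saturated amine ring at the end of that chain and left the number within the scatter. The other, a 1.1-fold higher number from compound 2 to compound 3 (0.04 log units; within the scatter), sits at a different place, the aromatic ring on the triazole, and was likewise within the scatter. Among the measured compounds shown here, nothing among the measured compounds tests a substituent on the saturated ring itself, so the expectation rests on how little the amine ring has mattered so far.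

Compound 4 is therefore expected to show a step of a 1.1-fold higher number from compound 2 to compound 4 (0.04 log units; within the scatter), not beyond the scatter. The estimate for compound 4 in this assay is 1200 nM, with a range of 600 nM to 2500 nM.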

Compound 4, half-maximal inhibitory concentration: 800 nM
For compound 4 the middle estimate is 1.5-fold (0.18 log units) above the measured one, within the range that was stated.
By their numbers in this assay, from the lowest: compounds 4, 1, 2 and 3 (each within the scatter of the next).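

In this assay, among these compounds, this is the first test of a substituent on the saturated amine ring: a methyl on the ring carbon three ring bonds from the ring nitrogen gives a 1.4-fold lower number from compound 2 to compound 4 (0.14 log units; within the scatter), so the added group produces no step beyond the scatter at this position. Compared with the smaller amine ring, 4-methylpiperidin-1-yl in place of pyrrolidin-1-yl gives a 1.1-fold lower number from compound 1 to compound 4 (0.03 log units; within the scatter), so compounds 1, 2 and 4 all lie within the scatter of one another, and the three amine end groups cannot be ranked in this assay. No evidence accompanies these values that would explain them.

As far as these compounds go, it remains open whether this insensitivity extends to groups other than methyl on the same ring carbon, such as a hydroxyl, an amine or a carboxylic acid, or to a morpholine or piperazine as the end group. A longer chain leading to the ring nitrogen is also untested among the compounds shown, as is the 4-methylpiperidin-1-yl group combined with the second fluoro of compound 3.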